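Methoxy gives way to ethylsulfanyl in compound 4

The source may report more compounds than this note shows. Statements on the series, on what has been measured and on what is new or still open speak of the compounds shown alone.

In a functional assay on MV4-11 cells (Homo sapiens) for inhibition, read by resazurin assay, with a stated time of 72 h (a higher number here means a weaker inhibitor of growth, a lower number a stronger inhibitor of growth), three compounds already have numbers. Compound 3 (`COc1ccc(Nc2nccc(-c3sc(OC)nc3C)n2)c(OC)c1`) stands at 1400 nM and compound 2 (`COc1ccc(N(C)c2nccc(-c3cn(C)c4ccccc34)n2)c(OC)c1`) at 2000 nM on the same scale, and these two values lie within the usual scatter of each other, so neither can be ranked over the other. Compound 1 (`COc1ccc(Nc2nccc(-c3c[nH]c4ccccc34)n2)c(OC(F)F)c1`) reads 4770 nM and this number is higher than that of compound 3 by more than the scatter.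

Compound 4 (`CCSc1nc(C)c(-c2ccnc(Nc3ccc(OC)cc3OC)n2)s1`) keeps everything in compound 3 except one group. It carries ethylsulfanyl in place of methoxy on an aromatic carbon of a five-membered aromatic ring with 1 nitrogen and 1 sulfur, next to the ring nitrogen and next to the ring sulfur (ethylsulfanyl in place of methoxy on an aromatic carbon). For the measured compounds named here, changing a single group is the simplest kind of comparison, but no two measured compounds differ in only one place, so the numbers so far do not show what such a swap does.

With nothing pointing either way, no shift beyond the scatter is expected in this assay for this change. The expected step is small (a 1.1-fold higher number from compound 3 to compound 4 (0.03 log units; within the scatter)) and carries no firm direction. For compound 4 the estimated value is 1500 nM with an expected range from 500 nM to 4500 nM as its likely span.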

Compound 4, concentration for 50% growth inhibition: 32400 nM
Compound 4: the middle estimate sits 22-fold (1.33 log units) below what was measured; the whole stated range lies below it.
By their numbers in this assay, from the lowest: compounds 3 and 2 (each within the scatter of the next); then compound 1; then compound 4.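

For the compounds shown here, this is the first single-group comparison in this assay, and it shows that the group on this aromatic carbon, next to the ring nitrogen and next to the ring sulfur, strongly affects the result: ethylsulfanyl in place of methoxy brings a 23-fold higher number from compound 3 to compound 4 (1.36 log units; beyond the scatter) and so a large loss of growth inhibition. The exchange is a modest one on paper, since the two groups have the same number of hydrogen-bond donors and acceptors and neither carries a net charge, so those counts do not separate them. No measurement shown here accounts for the size of this step.

Going by these compounds, it remains open which part of the change matters, the sulfur in place of oxygen or the longer chain, and the ethoxy and methylsulfanyl groups would separate the two. Also open, on these data alone, is whether a smaller or different group at this carbon, such as a plain hydrogen or an amine, would stay close to compound 3 at 1400 nM or move the number further in either direction.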